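Lengthening the chain on the piperidine series

This account rests on a few compounds, and the source may have more. Where it says the series, first, only, none or still open, it means among the compounds named here.

compound 1 `CN1CCN(CCN2CCC(c3cn(-c4ccc(F)cc4)c4ccc(Cl)cc34)CC2)C1=O` gives 0.021 umol/kg
compound 2 `O=C1NCCN1CCN1CCC(c2cn(-c3ccc(F)cc3)c3ccc(Br)cc23)CC1` gives 0.032 umol/kg
compound 3 `Fc1ccc(-n2cc(C3=CCNCC3)c3cc(C(F)(F)F)ccc32)cc1` gives > 0.86 umol/kg

Going by the values given here, in a functional assay on the whole organism for inhibition, with Rattus norvegicus as the target (a lower number here means that less compound is needed, a higher number that more compound is needed for the effect), compound 1 (0.021 umol/kg) lies within the scatter of compound 2, and these are the only two numbers. Compound 3 is reported only as a limit (> 0.86 umol/kg). Compound 4 `O=C1NCCN1CCCCCCN1CCC(c2cn(-c3ccc(F)cc3)c3ccc(Cl)cc23)CC1` is still to be measured. The change (4-(2-oxoimidazolidin-1-yl)butyl in place of 3-methyl-2-oxoimidazolidin-1-yl on a saturated chain carbon, two bonds along the chain from an amine nitrogen in a ring) puts 4-(2-oxoimidazolidin-1-yl)butyl in place of 3-methyl-2-oxoimidazolidin-1-yl on a saturated chain carbon, two bonds along the chain from an amine nitrogen in a ring. Among the compounds with values here, no measured step covers this change, so the expectation is loose. Compound 1 (0.021 umol/kg) leaves much room toward higher numbers in this assay, and a moderate move in that direction is expected. The expected step is a 7.1-fold higher number from compound 1 to compound 4 (0.85 log units; beyond the scatter), with wide margins. Estimated for compound 4: 0.15 umol/kg (range 0.03 umol/kg to 0.8 umol/kg).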

Compound 4, dose for half-maximal effect: > 2.2 umol/kg
Compound 4: a limit, no number; the forecaster's own chance of this, stated with the estimate: 20%; middle value at least 14-fold (1.16 log units) away from the limit.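

In this assay, going by these compounds alone, putting 4-(2-oxoimidazolidin-1-yl)butyl in place of 3-methyl-2-oxoimidazolidin-1-yl on this saturated chain carbon gives an at least 100-fold higher number from compound 1 to compound 4 (2.02 log units; beyond the scatter) as the first measured step at this position. This position therefore does not tolerate every such change to the chain carrying the oxoimidazolidinyl ring. The result for compound 4 is a limit, not a number: the limit of > 2.2 umol/kg in this assay, at which 1 of the 4 values shown sits.

The step combines a longer chain with loss of the ring methyl, and these two changes remain unseparated. On these data alone, whether a propyl chain, or a butyl chain with the ring methyl kept, would stay near compound 1 remains open.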